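A few compounds are considered here, and "the series" means these few. Any claim that something is new, unique, unknown or untested is made for them only; others in the source may bear on it.

Measured compounds:
Compound 1, `COc1cc(C)cc(-c2c(-c3ccnc(-c4ccc(C(C)=O)cc4)c3)cnn2CC#N)c1`: 101%
Compound 2, `COc1cc(C)cc(-c2nn(CC#N)cc2-c2ccc(-c3cccc(C(C)=O)c3)nc2)c1`: 97%
Compound 3, `Cc1cc(O)cc(-c2nn(CC#N)cc2-c2ccnc(-c3ccc(Oc4ccccc4)cc3)c2)c1`: 112%

In a functional assay on OVCAR-4 cells (Homo sapiens) for cytotoxicity, read by sulforhodamine B assay, with a stated time of 48 h, tested at 0.01 uM (a lower number here means a stronger effect, a higher number a weaker effect of the compound at the concentration tested), compound 3 gives the highest of the three numbers. Its nearest neighbour is compound 1, whose number is lower by a gap beyond the scatter; the furthest is compound 2, whose number is lower by a gap that is also beyond the scatter. All three read-outs sit close to the level of untreated cells.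

Compound 4, `Cc1cc(O)cc(-c2nn(CC#N)cc2-c2ccnc(-c3ccc(N(C)C)cc3)c2)c1`, has not yet been measured. It differs from compound 3 in one place: dimethylamino in place of phenoxy on an aromatic carbon. Among the measured compounds shown here, no step between two measured compounds describes this change, so nothing comparable is available. On the three numbers shown, any step in this assay is expected to be small, downward if at all, and not beyond the scatter. Compound 4 is therefore estimated at 103%, within a range of 88% to 118%, an expected step of a number 9 percentage points lower from compound 3 to compound 4 (within the scatter).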

Compound 4, a percentage reported as activity, at one concentration (the size of the read-out at that concentration, not a potency): 108%
For compound 4 the middle estimate is 5 percentage points below the measured one, and the stated range covers the measured number.
By their numbers in this assay, from the lowest: compounds 2, 1, 4 and 3 (each within the scatter of the next, the first and the last beyond it).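

In this assay, dimethylamino in place of phenoxy on an aromatic carbon gives a number 4 percentage points lower from compound 3 to compound 4 (within the scatter) in the first one-place comparison available here. At this position, the six-membered aromatic ring of phenoxy can therefore give way to a group with no ring without the read-out moving beyond the scatter. No measurement at hand bears on the reason for this result. Both compounds stay close to the level of untreated cells, so the comparison cannot show whether this position matters where the compounds have a clear effect. Going by these compounds, whether a carboxylic acid or a longer alkoxy chain on this carbon would change the read-out remains open.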